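A few compounds are considered here, and "the series" means these few. Any claim that something is new, unique, unknown or untested is made for them only; others in the source may bear on it.

Measured so far:
compound 1 `Cc1cc(C)c(NC(=O)N(Cc2ccc(-c3ccnn3C)cc2)C2CCCCCC2)c(C)c1` – < 1 mg/kg
compound 2 `Cc1cc(C)c(NC(=O)N(Cc2cccc(-c3ccnn3C)c2)C2CCCCCC2)c(C)c1` – > 1 mg/kg
compound 3 `Cc1cc(C)c(NC(=O)N(Cc2ccc(-c3cnn(C)c3)cc2)C2CCCCCC2)c(C)c1` – 0.31 mg/kg

In a functional assay on a cell-free system (plasma) with sterol O-acyltransferase, Soat (Rattus norvegicus) as the target (on this read-out lower numbers stand for an effect already at smaller amounts and higher numbers for an effect only at larger amounts of compound), compound 1 gives < 1 mg/kg, which is a limit of the assay (the limit of < 1 mg/kg in this assay, at which 1 of the 3 values shown sits). In this assay compound 2 gives > 1 mg/kg, also a limit (the limit of > 1 mg/kg in this assay, at which 1 of the 3 values shown sits). Compound 3 gives 0.31 mg/kg in this assay. The change from compound 1 to compound 3 is 1-methyl-1H-pyrazol-4-yl in place of 1-methyl-1H-pyrazol-5-yl on an aromatic carbon; its step, a step that the limit leaves unreadable from compound 1 to compound 3, cannot be sized. The difference between the cores of compound 1 and compound 2 is not broken down here.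

Compound 4 `Cc1cc(C)c(NC(=O)N(Cc2cccc(-c3cnn(C)c3)c2)C2CCCCCC2)c(C)c1` is not yet measured. It arises from compound 2 by 1-methyl-1H-pyrazol-4-yl in place of 1-methyl-1H-pyrazol-5-yl on an aromatic carbon, the same kind of change as from compound 1 to compound 3, but at a place meta to a large group rather than para to a large group. The earlier step gives no readable size, so the expectation rests on compound 2 and its limit > 1 mg/kg. The expected step is a step that the limit leaves unreadable from compound 2 to compound 4. Compound 4 is expected at 2 mg/kg, between 0.6 mg/kg and 7 mg/kg.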

Compound 4, dose for half-maximal effect: < 1 mg/kg
Compound 4: no number, only a limit (the forecaster's own chance of this, stated with the estimate: 50%); middle value at least 2.0-fold (0.30 log units) from the limit.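

In this assay compound 4 gives < 1 mg/kg, a limit of the assay and not a number. With 1-methyl-1H-pyrazol-4-yl in place of 1-methyl-1H-pyrazol-5-yl at the place meta to a large group, the result is a number no higher from compound 2 to compound 4 (the limit leaves the size open), so only a direction can be read on this core. The same change on the core of compound 1 has no readable size either, so whether the change carries over between cores with a similar size is not shown: the limit of < 1 mg/kg in this assay, at which 2 of the 4 values shown sit.

The compounds shown leave open how an amine or a carboxylic acid in place of the 1-methyl-1H-pyrazol-4-yl group would read in this assay. From the compounds shown here alone, a longer chain in place of the methyl on that ring also stays open.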